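The source may hold more compounds than are shown below. What is called first, only, known or untested is meant among the compounds shown, and "the series" means these compounds.

Compounds measured so far:
Compound 1, `Nc1cc(-c2ccccc2)nn1C(=O)c1csc(-c2ccccc2)n1`: 55.2%
Compound 2, `Nc1nnc(-c2csc(-c3ccccc3)n2)o1`: 21.4%

In a functional assay on the whole organism (strain Wistar albino) for inhibition, with Rattus norvegicus as the target, read by paw edema, with stated times of 1 h and 3 h, at a dose of 25 mg/kg by the oral route (on this read-out lower numbers stand for less inhibition and higher numbers for more inhibition at the one dose given (going by the name of the read-out)), compound 2 stands lowest of the two, with compound 1 a clear step higher, beyond the scatter. Compound 3, `c1ccc(-c2nc(-c3nnco3)cs2)cc1`, differs from compound 2 by hydrogen in place of amino on an aromatic carbon. For the measured compounds named here, no pair of measured compounds shows what this change does, so no size of step is known for it. A small step, downward if any, is expected, and it may well lie within the scatter. Compound 3 is therefore expected to give 17%, between 5% and 32%, which means an expected step of a number 4.4 percentage points lower from compound 2 to compound 3 (within the scatter).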

Compound 3, a percentage reported as inhibition, in the whole organism at one dose (the size of the read-out at that dose, not a potency): 27%
The estimate for compound 3 lay 10 percentage points below the measured number, and the stated range covers the measured number.
By their numbers in this assay, from the lowest: compounds 2 and 3 (each within the scatter of the next); then compound 1.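

Hydrogen in place of amino on this aromatic carbon gives a number 5.6 percentage points higher from compound 2 to compound 3 (within the scatter) in this assay. For this pair, the amino group next to the ring oxygen and ring nitrogen is thus not needed for the read-out to stay at this level at the one dose given. Nothing at hand explains this result. The compounds shown leave open whether a different group on this carbon, such as a methyl group, a carboxylic acid or a longer chain, would move the number beyond the scatter.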